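Sulfonyl tetrahydronaphthalene series: amine substituent step to compound 4

The source may report more compounds than this note shows. Statements on the series, on what has been measured and on what is new or still open speak of the compounds shown alone.

Measured compounds:
compound 1 `CC(=N)NCC1CCCc2cc(S(=O)(=O)c3ccccc3)ccc21` gives 0.631 nM in an assay on isolated protein for displacement of a labelled ligand from 5-hydroxytryptamine receptor 6 (Homo sapiens); a lower number here means a stronger inhibitor, a higher number a weaker inhibitor
compound 2 `NC[C@@H]1CCCc2cc(S(=O)(=O)c3cc[nH]c3)ccc21` gives 0.316 nM in this assay
compound 3 `COCCNC[C@@H]1CCCc2cc(S(=O)(=O)c3cccc(F)c3)ccc21` gives 0.251 nM in this assay

All three measured compounds share the sulfonyl-substituted core and differ in the aryl group on the sulfone and in the group on the chain nitrogen. Compound 3 has the lowest number of the three; the gap to compound 2 is within the scatter, so the two are not separable, while the gap to compound 1 is beyond the scatter.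

Compound 4 `NS(=O)(=O)NC[C@@H]1CCCc2cc(S(=O)(=O)c3cccc(F)c3)ccc21` is not yet measured. It keeps the aryl sulfone of compound 3 and alters the chain nitrogen only: sulfamoyl in place of 2-methoxyethyl on an amine nitrogen

Going by the values given here, no measured pair isolates a change at this nitrogen, so the step has to be guessed from the three values alone, all of which carry a group on that nitrogen that differs from sulfamoyl. The step from compound 3 to compound 4 is expected to be a loss, estimated at a 12-fold higher number from compound 3 to compound 4 (1.08 log units; beyond the scatter), with wide uncertainty because compound 3 sits at 0.251 nM and nothing in the set tests a sulfamoyl group. Compound 4 is therefore estimated at 3 nM, in a range from 0.5 nM to 20 nM.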

Compound 4, inhibition constant: 0.126 nM
For compound 4 the middle estimate is 24-fold (1.38 log units) above the measured one, and the stated range ends above it.
By their numbers in this assay, from the lowest: compounds 4, 3, 2 and 1 (each within the scatter of the next, the first and the last beyond it).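

In this assay, sulfamoyl in place of 2-methoxyethyl on an amine nitrogen gives a 2.0-fold lower number from compound 3 to compound 4 (0.30 log units; within the scatter), so the two groups cannot be separated at this position. Going by these compounds alone, this is the first step that isolates this nitrogen with the aryl sulfone held fixed, and it shows that a carbon-and-oxygen chain and a sulfur-containing group, which differ in their hydrogen-bond donor and acceptor counts, give values within the scatter of each other. No measurement shown here accounts for this result.

As far as these compounds go, one step at this nitrogen cannot show how far the position tolerates other groups, so it remains open how a methanesulfonyl group, an acetyl group or a longer chain would read on the same aryl sulfone. From the compounds shown here alone, it also remains open whether sulfamoyl behaves the same way with the pyrrole or unsubstituted phenyl sulfones seen in the other compounds.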